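A Ring-Opened Guanidine Analogue at the Serotonin-6 Receptor

A few compounds are considered here, and "the series" means these few. Any claim that something is new, unique, unknown or untested is made for them only; others in the source may bear on it.

In an assay on isolated protein for displacement of a labelled ligand from 5-hydroxytryptamine receptor 6 (Homo sapiens) (a lower number here means a stronger inhibitor, a higher number a weaker inhibitor), the three measured compounds stand as follows:
compound 1, `NC[C@@H]1CCCc2cc(S(=O)(=O)c3cccc(O)c3)ccc21`, gives 0.251 nM
compound 2, `N#Cc1cccc(S(=O)(=O)c2ccc3c(c2)CCC[C@H]3C=N)c1`, gives 0.501 nM
compound 3, `O=C1CN=C(NC[C@@H]2CCCc3cc(S(=O)(=O)c4cccc(F)c4)ccc32)N1`, gives 0.1 nM

Compound 3 has the lowest number of the three. Its nearest neighbour is compound 1, whose value lies beyond the scatter above it, and the furthest is compound 2, further still. Compound 3 is therefore the strongest binder among the measured set.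

Compound 4, `N=C(N)NC(=O)C[C@@H]1CCCc2cc(S(=O)(=O)c3cccc(F)c3)ccc21`, is not yet measured. It differs from compound 3 in one place: a group of 6 heavy atoms (2 carbon, 3 nitrogen, 1 oxygen; no ring) in place of a group of 7 heavy atoms (3 carbon, 3 nitrogen, 1 oxygen; one five-membered non-aromatic ring with 2 hetero atoms), on a saturated chain carbon bound to a saturated ring carbon. The shared core with its fluorinated sulfonyl aryl group is kept, and both compounds carry a guanidine-type fragment on the same chain carbon; what changes is that the five-membered ring of compound 3 is opened into an acyclic acylguanidine in compound 4.

Within the data shown here, no measured pair in this set tracks such a change. The ring-bearing group gave the lowest number, while the simpler amine and imine of compound 1 and compound 2 sit higher; the expectation is that compound 4 lands between them, a modest loss. The step from compound 3 to compound 4 is expected to be a 5.0-fold higher number from compound 3 to compound 4 (0.70 log units; beyond the scatter). Compound 4 is estimated at 0.5 nM, within 0.1 nM to 3 nM.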

Compound 4, inhibition constant: 0.631 nM
Compound 4: the middle estimate sits 1.3-fold (0.10 log units) below what was measured; measured number inside the range.
By their numbers in this assay, from the lowest: compound 3; then compounds 1, 2 and 4 (each within the scatter of the next, the first and the last beyond it).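

Among these compounds, replacing the ring-bearing group by the open-chain group, on a saturated chain carbon bound to a saturated ring carbon, gives a 6.3-fold higher number from compound 3 to compound 4 (0.80 log units; beyond the scatter) in this assay, the first step in this set that can be read at a single place. It shows that binding at this position responds to the change, yet compound 4 still gives 0.631 nM, so the five-membered non-aromatic ring is not required for a low number. Nothing available accounts for the size of this step.

The two groups differ in their ring and also in their counts of donors and acceptors, and this single pair cannot separate those differences. From the compounds shown here alone, whether a plain guanidine without the carbonyl, or a six-membered cyclic guanidine, would keep the lower number remains open.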